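A few compounds are considered here, and "the series" means these few. Any claim that something is new, unique, unknown or untested is made for them only; others in the source may bear on it.

Measured in a functional assay on MDA-MB-435 cells (Homo sapiens) for inhibition, read by sulforhodamine B assay, with a stated time of 48 h (a lower number here means a stronger inhibitor of growth, a higher number a weaker inhibitor of growth), each value a limit of the assay and not a number:

- compound 1 `CN(C)/C=C/C(=O)c1nn(-c2ccccc2)c(-c2ccccc2)c1C#N`: > 100000 nM
- compound 2 `Cc1nnc(-c2nn(-c3ccccc3)c(-c3ccccc3)c2C#N)c2cn(-c3ccccc3)nc12`: > 100000 nM
- compound 3 `N#Cc1c(-c2nnc(O)c3nn(-c4ccc(Cl)cc4)cc23)nn(-c2ccccc2)c1-c1ccccc1`: > 100000 nM

Compound 2 has no number in this assay, only the limit > 100000 nM. Compound 1 and compound 3 end the same way, and the whole set sits at one ceiling: the limit of > 100000 nM in this assay, at which 3 of the 3 values shown sit. Compound 4 `N#Cc1c(-c2nnc(-c3ccccc3)c3nn(-c4ccccc4)cc23)nn(-c2ccccc2)c1-c1ccccc1` is not yet measured. It differs from compound 2 by phenyl in place of methyl on an aromatic carbon. For the measured compounds named here, no measured pair shows a step, and none beyond the scatter is expected in this assay. The expected step is a number no higher from compound 2 to compound 4 (the limit leaves the size open). The estimate for compound 4 is 100000 nM, with an expected range of 30000 nM to 150000 nM.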

Compound 4, concentration for 50% growth inhibition: 31800 nM
Compound 4: the middle estimate sits 3.1-fold (0.50 log units) above what was measured; low and high end bracket the measured number.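

For the compounds shown here, compound 4 gives the only actual number in the set in this assay, which shows that this position, on the aromatic carbon next to the ring nitrogen, can move the read-out: phenyl in place of methyl gives an at least 3.1-fold lower number from compound 2 to compound 4 (0.49 log units; beyond the scatter). That step is only a minimum, because compound 2 carries a limit and not a number: the limit of > 100000 nM in this assay, at which 3 of the 4 values shown sit.

Open, from the compounds shown here alone, is how an amine, a morpholine or a longer alkyl chain at this position would read in this assay. Also open, going by these compounds, is whether a substituted phenyl would lower the number further.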